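The source may hold more compounds than are shown below. What is called first, only, known or untested is meant among the compounds shown, and "the series" means these compounds.

Measured compounds:
- compound 1, `CCNC(=O)C1=C(C)NC(=O)NC1c1ccco1`: 2%
- compound 2, `CCNC(=O)C1=C(C)NC(=O)NC1c1cccs1`: 1%
- compound 3, `CCNC(=O)C1=C(C)NC(=O)NC1c1ccsc1`: 3%

All three share one core and differ only in the aromatic ring on a saturated ring carbon. In an assay on membranes from CHO cells for displacement of a labelled ligand from adenosine receptor A1 (Homo sapiens), read by scintillation counting, with a stated time of 60 min, tested at 1 uM (on this read-out lower numbers stand for less inhibition and higher numbers for more inhibition at the one concentration tested (going by the name of the read-out)), compound 1 gives 2%, and its values sit within the scatter of both neighbours: a number 1 percentage points lower from compound 1 to compound 2 (within the scatter) and a number 1 percentage points higher from compound 1 to compound 3 (within the scatter). The step of a number 2 percentage points higher from compound 2 to compound 3 (within the scatter) is likewise within the scatter, so the three numbers are indistinguishable and all low.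

Compound 4, `CCSC(=O)C1=C(C)NC(=O)NC1c1ccco1`, differs from compound 1 at another place: ethylsulfanyl in place of ethylamino on a carbonyl carbon. Among the measured compounds shown here, none of the measured steps touches this carbonyl substituent; each of them swaps the aromatic ring on the saturated ring carbon, and each was within the scatter. For the measured compounds named here, no measured step therefore bears directly on this change, and nothing in these numbers points to a gain in this assay.

Compound 4 is expected to stay near the common low level, with an estimated a number 1 percentage points higher from compound 1 to compound 4 (within the scatter), that is, no step beyond the scatter. The expected value for compound 4 is 3%, in a range from -5% to 12%.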

Compound 4, a percentage reported as inhibition, at one concentration (the size of the read-out at that concentration, not a potency): 6%
Compound 4: middle estimate off by 3 percentage points, on the low side, and the stated range covers the measured number.
By their numbers in this assay, from the lowest: compounds 2, 1, 3 and 4 (each within the scatter of the next).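

This is the first change shown at the carbonyl substituent rather than at the aromatic ring, and in this assay ethylsulfanyl in place of ethylamino reads as a number 4 percentage points higher from compound 1 to compound 4 (within the scatter). Giving up the hydrogen-bond donor counted on ethylamino therefore brings no change that can be told from scatter, although numbers this low say little about what this position can contribute. Nothing measured here offers an explanation for this result.

On these data alone, what a benzylamino group, a longer chain such as butylamino or an ethoxy group would do on this carbonyl carbon remains open. As far as these compounds go, it is also open whether ethylsulfanyl would read the same alongside thiophen-2-yl or thiophen-3-yl on the saturated ring carbon.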